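A Hydroxy Group Added to an Inactive Scaffold

This account rests on a few compounds, and the source may have more. Where it says the series, first, only, none or still open, it means among the compounds named here.

Compound 1 `CSc1nc2c(C)nsc2n1[C@H]1C[C@H](O)[C@@H](CO)O1` is one of three close relatives tested in a functional assay on HFF cells (Homo sapiens) for inhibition; on this read-out lower numbers stand for stronger inhibition and higher numbers for weaker inhibition. In this assay compound 1 gives > 100000 nM, which is a limit of the assay and not a number. Compound 2 `CSc1nc2cnsc2n1[C@H]1C[C@H](O)[C@@H](CO)O1` differs from compound 1 by hydrogen in place of methyl on an aromatic carbon. In this assay compound 2 gives > 100000 nM, again a limit rather than a number. Compound 3 `Cc1nsc2c1nc(SCc1ccccc1)n2[C@H]1C[C@H](O)[C@@H](CO)O1` carries phenyl in place of hydrogen on a saturated chain carbon bound to a sulfur. In this assay compound 3 gives > 100000 nM, also a limit. The two steps a step that the two limits leave unreadable from compound 1 to compound 2 and a step that the two limits leave unreadable from compound 1 to compound 3 therefore cannot be sized, since (the limit of > 100000 nM in this assay, at which 3 of the 3 values shown sit).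

Compound 4 `CSc1nc2c(C)nsc2n1[C@@H]1O[C@H](CO)[C@@H](O)[C@@H]1O` differs from compound 1 in one place: hydroxy in place of hydrogen on a saturated ring carbon. Among the measured compounds shown here, no measured step touches the five-membered ring, so nothing among the three measurements says how this change acts on the read-out. With every measured neighbour of compound 1 sitting at the limit, the expected result for compound 4 is that it too stays at the limit, an estimated step that the limit leaves unreadable from compound 1 to compound 4. The estimate for compound 4 is 150000 nM, expected to lie between 50000 nM and 500000 nM.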

Compound 4, half-maximal inhibitory concentration: > 100000 nM
Compound 4 was reported as a limit (the forecaster's own chance of this, stated with the estimate: 85%); the middle value is on the limit's open side.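

Compound 4 sits at the same limit as compound 1, and a limit is not a number, so no size can be read for the hydroxy in place of hydrogen on the saturated ring carbon: the limit of > 100000 nM in this assay, at which 4 of the 4 values shown sit. The compounds shown leave open how strongly any of them acts in this assay, and which change to the shared core, if any, would give a readable value.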